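The compounds below may be only part of what the source reports. "The series", "measured", "known", "first", "only" and "open" are said of these compounds alone.

Values in a functional assay on CCRF-CEM cells (Homo sapiens) for antiproliferative activity, read by fluorescence and resazurin assay, with a stated time of 48 h (a lower number here means a stronger inhibitor, a higher number a weaker inhibitor), for the measured compounds:

compound 1, `O=C(N/N=C/c1ccncc1)c1cc2cc(Br)ccc2oc1=O`: 6340 nM
compound 2, `O=C(N/N=C/c1cccnc1)c1cc2cc(Br)ccc2oc1=O`: 3710 nM
compound 3, `CCOc1ccc2nc(Cl)c(/C=N/NC(=O)c3cc4ccccc4oc3=O)cc2c1`: 6320 nM

Compound 2 carries the lowest of the three numbers, but its separation from compound 1 and from compound 3 is within the scatter, so no order among the three can be claimed. Within the data shown here, the only single-point step in the set, a 1.7-fold lower number from compound 1 to compound 2 (0.23 log units; within the scatter), is itself within the scatter.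

Compound 4, `O=C(N/N=C/c1cccnc1)c1cc2ccccc2oc1=O`, differs from compound 2 by hydrogen in place of bromo on an aromatic carbon. Among the measured compounds shown here, no measured step removes a bromo substituent: compound 3 lacks bromo but also differs from compound 2 in several other places, so the two values give no clean comparison. No step beyond the scatter is therefore expected for compound 4, a 1.2-fold higher number from compound 2 to compound 4 (0.08 log units; within the scatter). Compound 4 is estimated at 4500 nM, range 1500 nM to 14000 nM.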

Compound 4, half-maximal inhibitory concentration: 9900 nM
Compound 4: the middle estimate sits 2.2-fold (0.34 log units) below what was measured, and the stated range covers the measured number.
By their numbers in this assay, from the lowest: compounds 2, 3, 1 and 4 (each within the scatter of the next, the first and the last beyond it).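

Hydrogen in place of bromo on this aromatic carbon gives a 2.7-fold higher number from compound 2 to compound 4 (0.43 log units; beyond the scatter) as the only step in the series beyond the scatter, though a modest one. Among these compounds, in this single pair, bromo at this position goes with the lower number, which the earlier compounds could not show, as none of their comparisons isolated this change. Nothing measured here accounts for the step.

From the compounds shown here alone, only bromo and hydrogen can be compared at this position, so the effect of a methoxy group or an amine there remains open. Also open, going by these compounds, is whether the same step would appear with the pyridin-4-yl group of compound 1.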